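This account rests on a few compounds, and the source may have more. Where it says the series, first, only, none or still open, it means among the compounds named here.

Measured so far:
- compound 1, `O=C(Cc1csc2nc(-c3ccc(Br)cc3)cn12)N/N=C/c1ccccc1O`: 3630 nM
- compound 2, `O=C(Cc1csc2nc(-c3ccc(Br)cc3)cn12)N/N=C/c1ccc(O)cc1`: 21400 nM
- compound 3, `COc1cccc(OC)c1/C=N/NC(=O)Cc1csc2nc(-c3ccc(Br)cc3)cn12`: 13800 nM

In a functional assay on U-251 cells (Homo sapiens) for inhibition, read by sulforhodamine B assay, with a stated time of 48 h (on this read-out lower numbers stand for stronger inhibition of growth and higher numbers for weaker inhibition of growth), compound 1 gives the lowest number of the three, so it is the strongest inhibitor of growth here. Its steps to the others are both beyond the scatter: a 5.9-fold higher number from compound 1 to compound 2 (0.77 log units; beyond the scatter) and a 3.8-fold higher number from compound 1 to compound 3 (0.58 log units; beyond the scatter). Compounds 2 and 3 sit within the scatter of each other, as a 1.6-fold lower number from compound 2 to compound 3 (0.19 log units; within the scatter) shows.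

Compound 4, `O=C(Cc1csc2nc(-c3ccc(Br)cc3)cn12)N/N=C/c1ccc(Cl)cc1Cl`, has not been measured in this assay. It differs from compound 1 in one place: 2,4-dichlorophenyl in place of 2-hydroxyphenyl on a carbon with a double bond to nitrogen

Both measured steps that start from compound 1 replace the 2-hydroxyphenyl and both give a higher number. Neither of them puts a group without hydrogen-bond donors or acceptors in this place, so the change to 2,4-dichlorophenyl is further from anything measured. On the two steps from compound 1, a step towards a higher number is expected for compound 4 as well, a 2.8-fold higher number from compound 1 to compound 4 (0.44 log units; beyond the scatter), with a wide range. Compound 4 is therefore estimated at 10000 nM in this assay, between 2500 nM and 40000 nM.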

Compound 4, concentration for 50% growth inhibition: 20400 nM
For compound 4 the middle estimate is 2.0-fold (0.31 log units) below the measured one; measured number inside the range.
By their numbers in this assay, from the lowest: compound 1; then compounds 3, 4 and 2 (each within the scatter of the next).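

In this assay, the step of a 5.6-fold higher number from compound 1 to compound 4 (0.75 log units; beyond the scatter) shows that swapping the 2-hydroxyphenyl for a ring with 0 hydrogen-bond donors and 0 hydrogen-bond acceptors also loses growth inhibition. The steps of a 1.5-fold higher number from compound 3 to compound 4 (0.17 log units; within the scatter) and a 1.0-fold lower number from compound 2 to compound 4 (0.02 log units; within the scatter) are both within the scatter, so the 2,4-dichlorophenyl, 2,6-dimethoxyphenyl and 4-hydroxyphenyl compounds cannot be told apart, even though only compound 2 among them keeps a hydroxyl, and of the four compounds shown only compound 1 stands apart. Nothing available explains why the 2-hydroxyphenyl group differs from the other three.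

Going by these compounds, it remains open whether an amine or a single methoxy group in place of the hydroxyl of compound 1 would keep its activity. On these data alone, it is also open whether a plain alkyl chain could replace the aromatic ring here.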